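The source may hold more compounds than are shown below. What is called first, only, known or untested is meant among the compounds shown, and "the series" means these compounds.

Compound 1 `COc1ccc(C(=O)N=C(N)N)cc1S(C)(=O)=O`: 270 nM in a functional assay for inhibition of sodium/hydrogen exchanger (Oryctolagus cuniculus); a higher number here means a weaker inhibitor, a lower number a stronger inhibitor
Compound 2 `CS(=O)(=O)c1cc(C(=O)N=C(N)N)ccc1Oc1cccnc1`: 76 nM
Compound 3 `Cc1ccc(C(=O)N=C(N)N)cc1S(C)(=O)=O`: 210 nM

Compound 3 and compound 1 sit together, the step of a 1.3-fold lower number from compound 1 to compound 3 (0.11 log units; within the scatter) lying within the scatter, while the step of a 2.8-fold higher number from compound 2 to compound 3 (0.44 log units; beyond the scatter) sets compound 3 apart from compound 2. Compound 4 `CS(=O)(=O)c1cc(C(=O)N=C(N)N)ccc1Cl` differs from compound 3 by chloro in place of methyl on an aromatic carbon. Within the data shown here, the only measured step at that carbon not bringing in a ring is a 1.3-fold lower number from compound 1 to compound 3 (0.11 log units; within the scatter), within the scatter; the steps of a 3.6-fold lower number from compound 1 to compound 2 (0.55 log units; beyond the scatter) and a 2.8-fold higher number from compound 2 to compound 3 (0.44 log units; beyond the scatter) each involve a (pyridin-3-yl)oxy group and bear less on a chloro for methyl swap. No step beyond the scatter is therefore expected in this assay. The step expected is a 1.2-fold lower number from compound 3 to compound 4 (0.07 log units; within the scatter). For compound 4 in this assay the expected value is 180 nM, between 90 nM and 360 nM.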

Compound 4, half-maximal inhibitory concentration: 380 nM
Compound 4: middle estimate off by 2.1-fold (0.32 log units), on the low side, and the stated range ends below it.
By their numbers in this assay, from the lowest: compound 2; then compounds 3, 1 and 4 (each within the scatter of the next).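

At this aromatic carbon, ortho to a methylsulfonyl group, chloro, methyl and methoxy are not separated in this assay: a 1.8-fold higher number from compound 3 to compound 4 (0.26 log units; within the scatter) and a 1.4-fold higher number from compound 1 to compound 4 (0.15 log units; within the scatter) both stay within the scatter. The (pyridin-3-yl)oxy group does stand apart from chloro, with a 5.0-fold higher number from compound 2 to compound 4 (0.70 log units; beyond the scatter) beyond the scatter, so among these four compounds only compound 2 departs from the rest. Nothing available gives a reason for these steps.

As far as these compounds go, whether an amine, a carboxylic acid or a longer chain at this carbon would stay with the three ringless groups remains open. So does whether a phenoxy group would match the (pyridin-3-yl)oxy group.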